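From 2,3-dimethoxyphenyl to 2,4-dimethoxyphenyl

This account rests on a few compounds, and the source may have more. Where it says the series, first, only, none or still open, it means among the compounds named here.

Measured in a functional assay on HeLa cells (Homo sapiens) for inhibition, read by MTT assay, with a stated time of 48 h; on this read-out higher numbers stand for weaker inhibition and lower numbers for stronger inhibition:
Compound 1 `Brc1ccc2[nH]cc(C(c3ccccc3)c3c[nH]c4ccc(Br)cc34)c2c1` gives 900 nM
Compound 2 `COc1cccc(C(c2c[nH]c3ccc(Br)cc23)c2c[nH]c3ccc(Br)cc23)c1OC` gives 64500 nM

Compound 2 holds the higher of the two numbers in this assay, well clear of compound 1. Compound 3 `COc1ccc(C(c2c[nH]c3ccc(Br)cc23)c2c[nH]c3ccc(Br)cc23)c(OC)c1` is its isomer, and the change is this: 2,4-dimethoxyphenyl in place of 2,3-dimethoxyphenyl on a saturated chain carbon bound to two aromatic carbons. Going by the values given here, the only measured step that bears on it is the large one, a 72-fold higher number from compound 1 to compound 2 (1.86 log units; beyond the scatter), which replaced phenyl with 2,3-dimethoxyphenyl. Among the compounds with values here, no measured pair compares two dimethoxyphenyl groups, so a smaller move toward lower numbers is expected, with much uncertainty. The expected step is a 2.6-fold lower number from compound 2 to compound 3 (0.41 log units; beyond the scatter). The estimate for compound 3 is 25000 nM, with a range from 4000 nM to 90000 nM.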

Compound 3, half-maximal inhibitory concentration: 63200 nM
Compound 3: the middle estimate sits 2.5-fold (0.40 log units) below what was measured; the measured number falls inside the stated range.
By their numbers in this assay, from the lowest: compound 1; then compounds 3 and 2 (each within the scatter of the next).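

In this assay, 2,4-dimethoxyphenyl in place of 2,3-dimethoxyphenyl on the saturated chain carbon gives a 1.0-fold lower number from compound 2 to compound 3 (0.01 log units; within the scatter), so this assay does not tell the two isomers apart. In place of phenyl, 2,4-dimethoxyphenyl gives a 70-fold higher number from compound 1 to compound 3 (1.85 log units; beyond the scatter), so the large gap from phenyl holds for both dimethoxyphenyl groups. Nothing available explains this result. The compounds shown leave open where a single methoxy group would fall at this position, and whether a hydroxyl or an amine on the phenyl ring would stay nearer compound 1 or nearer compound 2.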